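The source may report more compounds than this note shows. Statements on the series, on what has been measured and on what is new or still open speak of the compounds shown alone.

Compound 1, `NS(=O)(=O)c1ccc(N2N=C(c3ccc(OCc4ccccc4)cc3)CC2c2ccc(F)cc2)cc1`: in an ADME assay on MT4 cells (Homo sapiens) for cytotoxicity, read by MTT assay, with a stated time of 96 h (a higher number here means that more compound is tolerated, a lower number that less compound is tolerated), compound 1 gives only a limit, > 100000 nM.
Compound 2, `NS(=O)(=O)c1ccc(N2N=C(c3ccc(Oc4ccccc4)cc3)CC2c2ccc(F)cc2)cc1`: compound 2 gives 33000 nM.
Compound 3, `Cc1cccc(C2CC(c3ccccc3)=NN2c2ccc(S(N)(=O)=O)cc2)c1`: compound 3 gives 37000 nM.

Compound 1 thus stands at the upper edge of what the measurement reports, as one of the three values at the limit of > 100000 nM in this assay, at which 1 of the 3 values shown sits. The step of an at least 3.0-fold lower number from compound 1 to compound 2 (0.48 log units; beyond the scatter) is the only measured one, and it alters the oxygen substituent, not the saturated ring carbon. Compound 4, `Cc1ccccc1C1CC(c2ccc(OCc3ccccc3)cc2)=NN1c1ccc(S(N)(=O)=O)cc1`, differs from compound 1 by 2-methylphenyl in place of 4-fluorophenyl on a saturated ring carbon. Among the measured compounds shown here, no measured step touches this position, so no change beyond the scatter is expected. Compound 4 is therefore estimated at 100000 nM, between 40000 nM and 250000 nM, which means an expected step of a number no higher from compound 1 to compound 4 (the limit leaves the size open).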

Compound 4, half-maximal cytotoxic concentration: >= 100000 nM
Compound 4: a limit, no number; the forecaster's own chance of this, stated with the estimate: 55%; the middle value sits exactly at the limit.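

Compound 1 and compound 4 each give only a limit, not a number, and the step between them cannot be read. The compounds shown leave open whether 2-methylphenyl in place of 4-fluorophenyl changes how much compound is tolerated.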